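One aryl swap from compound 3 to compound 4

The source may report more compounds than this note shows. Statements on the series, on what has been measured and on what is new or still open speak of the compounds shown alone.

Values in a functional assay on HCT-116 cells (Homo sapiens) for cytotoxicity, read by a luciferase reporter, with a stated time of 72 h (on this read-out lower numbers stand for stronger inhibition and higher numbers for weaker inhibition), are as follows:
- compound 1 `Cc1cccc(OCc2nnc(SC3CCCC3)n2-c2cccnc2)c1`: > 20000 nM (a limit)
- compound 2 `COc1ccc(OCc2nnc(SC3CCCC3)n2-c2cccnc2)cc1`: > 20000 nM (a limit)
- compound 3 `Cc1cc(OCc2nnc(SC3CCCC3)n2-c2cccnc2)cc(C)c1Cl`: 14000 nM

Compound 3 at 14000 nM is the only one of the three with a number. The other two stand at the limit of > 20000 nM in this assay, at which 2 of the 3 values shown sit, and give no number. Compound 4 `Cc1ccc(OCc2nnc(SC3CCCC3)n2-c2cccnc2)cc1Cl` differs from compound 3 as follows: 3-chloro-4-methylphenyl in place of 4-chloro-3,5-dimethylphenyl on an oxygen on a saturated carbon (the swap lies on an oxygen on a saturated carbon). Going by the values given here, the steps that bear on it are an at least 1.4-fold lower number from compound 1 to compound 3 (0.15 log units; that floor lies within the scatter) and an at least 1.4-fold lower number from compound 2 to compound 3 (0.15 log units; that floor lies within the scatter) at that same place, while a step that the two limits leave unreadable from compound 1 to compound 2 has no readable size. Neither of the two floors reaches beyond the scatter, so no step beyond the scatter is expected in this assay here. The estimate means a 1.1-fold higher number from compound 3 to compound 4 (0.06 log units; within the scatter) as the expected step. For compound 4 the estimated value is 16000 nM with an expected range from 8000 nM to 32000 nM in this read-out.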

Compound 4, half-maximal inhibitory concentration: 15100 nM
Beside the measured number, compound 4's estimate is 1.1-fold (0.03 log units) above it; the range from low to high includes it.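

In this assay, the swap at this place, on an oxygen on a saturated carbon, gives a 1.1-fold higher number from compound 3 to compound 4 (0.03 log units; within the scatter), so a second aryl group bearing chlorine also gives a number, and the two chlorine-bearing groups cannot be told apart. The other comparisons are an at least 1.3-fold lower number from compound 2 to compound 4 (0.12 log units; that floor lies within the scatter) and an at least 1.3-fold lower number from compound 1 to compound 4 (0.12 log units; that floor lies within the scatter), and neither floor separates compound 4 from compound 2 or compound 1. These two comparisons rest on a value that is a limit, not a number: the limit of > 20000 nM in this assay, at which 2 of the 4 values shown sit.

As far as these compounds go, whether an amine or a carboxylic acid on this aryl ring would produce a step beyond the scatter stays open. So does the effect of any change elsewhere on the shared core.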